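Bromine on the Far Side of the Phenyl Ring

A few compounds are considered here, and "the series" means these few. Any claim that something is new, unique, unknown or untested is made for them only; others in the source may bear on it.

Of the compounds shown here, three built on one shared core have been tested in a functional assay on SGC-7901 cells (Homo sapiens) for inhibition, read by MTT assay, with a stated time of 24 h; on this read-out lower numbers stand for stronger inhibition and higher numbers for weaker inhibition. Compound 1 `COc1ccc(-n2cc(CN3C(=O)C[C@@H]4CC[C@@]3(C)C4(C)C)nn2)cc1` gives 480 nM, compound 2 `CC1(C)[C@H]2CC[C@]1(C)N(Cc1cn(-c3ccccc3)nn1)C(=O)C2` gives 240 nM, and compound 3 `CC1(C)[C@H]2CC[C@]1(C)N(Cc1cn(-c3cccc(Br)c3)nn1)C(=O)C2` gives 120 nM. Compound 2 therefore stands second highest of the three numbers, and both its neighbours lie within the scatter: compound 1 sits a step higher, a 2.0-fold lower number from compound 1 to compound 2 (0.30 log units; within the scatter), and compound 3 a step lower, a 2.0-fold lower number from compound 2 to compound 3 (0.30 log units; within the scatter).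

The untested compound 4 `CC1(C)[C@H]2CC[C@]1(C)N(Cc1cn(-c3ccc(Br)cc3)nn1)C(=O)C2` differs from compound 2 in one place: bromo in place of hydrogen on an aromatic carbon. The bromine now sits on the aromatic carbon that is para to a large group, so the phenyl becomes 4-bromophenyl. Going by the values given here, the closest precedent is the move from compound 2 to compound 3, where a bromine was added at a different carbon of the same ring, a 2.0-fold lower number from compound 2 to compound 3 (0.30 log units; within the scatter), a change that did not rise above the scatter. The only other substituent tried at the para position is the methoxy of compound 1, whose number is also within the scatter of compound 2. Nothing in these steps points to a change larger than the scatter in this assay, so compound 4 is expected to show a 1.2-fold lower number from compound 2 to compound 4 (0.08 log units; within the scatter), leaning slightly toward the bromine-bearing compound 3. Compound 4 is therefore estimated at 200 nM, with a range from 80 nM to 500 nM.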

Compound 4, half-maximal inhibitory concentration: 450 nM
Beside the measured number, compound 4's estimate is 2.3-fold (0.35 log units) below it, and the stated range covers the measured number.
By their numbers in this assay, from the lowest: compounds 3, 2, 4 and 1 (each within the scatter of the next, the first and the last beyond it).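

Bromine's place on the ring matters more here than its presence: in this assay, shifting it from the 3-bromophenyl of compound 3 to the 4-bromophenyl gives a 3.8-fold higher number from compound 3 to compound 4 (0.57 log units; beyond the scatter) and separates two compounds that carry the same atoms. At the aromatic carbon para to a large group, adding bromine to the plain phenyl gives a 1.9-fold higher number from compound 2 to compound 4 (0.27 log units; within the scatter) and so does not clearly shift the result, while bromo in place of methoxy at that carbon gives a 1.1-fold lower number from compound 1 to compound 4 (0.03 log units; within the scatter) and leaves those two substituents indistinguishable. Nothing available explains why the two bromine placements part ways.

Going by these compounds, whether an amine, a carboxylic acid or a longer chain on that same para carbon could rise beyond the scatter from the plain phenyl of compound 2 remains open. Also open, on these data alone, is whether the ring carbon that holds bromine in compound 3 would give similar numbers with groups other than bromine, such as a methoxy or a chloro.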